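Lengthening the chain on the chloro compound

The source may report more compounds than this note shows. Statements on the series, on what has been measured and on what is new or still open speak of the compounds shown alone.

In a functional assay on A549 cells (Homo sapiens) for antiproliferative activity, read by MTT assay, with a stated time of 48 h (on this read-out higher numbers stand for weaker inhibition and lower numbers for stronger inhibition), compound 3 (`CCCCC1(O)C(=O)Nc2ccc(Nc3ccc(Cl)cc3)cc21`) gives 2800 nM as the lowest of the three numbers, beyond the scatter from both others. Compound 2 (`CCCCCC1(O)C(=O)Nc2ccc(Nc3ccc(F)cc3)cc21`) gives 5900 nM and compound 1 (`CCCCCC1(O)C(=O)Nc2ccc(Nc3ccc(C)cc3)cc21`) gives 8100 nM on the same read-out.

Compound 4 (`CCCCCC1(O)C(=O)Nc2ccc(Nc3ccc(Cl)cc3)cc21`) differs from compound 3 by one change: methyl in place of hydrogen on a saturated chain carbon, four bonds along the chain from a saturated ring carbon.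

Among the compounds with values here, the only measured step in one place is a 1.4-fold lower number from compound 1 to compound 2 (0.14 log units; within the scatter) and it concerns the aromatic substituent, so no measured step isolates the chain. Compound 2 at 5900 nM shares the chain of compound 4 but not its aromatic substituent, which gives a weak lean towards a higher number. No step beyond the scatter is therefore expected in this assay for this change. The estimated step is a 1.3-fold higher number from compound 3 to compound 4 (0.10 log units; within the scatter) on this reasoning. Compound 4 is estimated at 3500 nM with an expected range from 1800 nM to 7000 nM on this read-out.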

Compound 4, half-maximal inhibitory concentration: 1900 nM
Compound 4: middle estimate off by 1.8-fold (0.27 log units), on the high side, and the stated range covers the measured number.
By their numbers in this assay, from the lowest: compounds 4 and 3 (each within the scatter of the next); then compounds 2 and 1 (each within the scatter of the next).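

In this assay, methyl in place of hydrogen on a saturated chain carbon, four bonds along the chain from a saturated ring carbon, gives a 1.5-fold lower number from compound 3 to compound 4 (0.17 log units; within the scatter) and so shows no step beyond the scatter at this position on the chloro compounds. With the chain held the same, the aromatic substituent now gives steps beyond the scatter, namely a 3.1-fold lower number from compound 2 to compound 4 (0.49 log units; beyond the scatter) and a 4.3-fold lower number from compound 1 to compound 4 (0.63 log units; beyond the scatter) on the chloro side, while the fluoro and methyl compounds remain within the scatter of each other. No supporting measurement bears on these steps.

Going by these compounds, whether a longer chain, or an amine or carboxylic acid on the chain, would keep the number of compound 4 remains open. Also open, on these data alone, is how bromo or trifluoromethyl on the aromatic carbon would compare with chloro.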